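From an amino link to a benzyl link on the core

The source may report more compounds than this note shows. Statements on the series, on what has been measured and on what is new or still open speak of the compounds shown alone.

The three measured compounds share one core and differ only in the group attached to one aromatic carbon of it. Compound 1 `COc1ccc(Oc2ccc3cc(NC(=O)c4ccc(OC(C)=O)c(CC=C(C)C)c4)c(=O)oc3c2C)cc1` carries a 4-methoxyphenoxy group, and in a functional assay on MCF7 cells (Homo sapiens) for antiproliferative activity (a higher number here means a weaker inhibitor, a lower number a stronger inhibitor), compound 1 gives 18200 nM. Compound 2 `COc1cccc(Oc2ccc3cc(NC(=O)c4ccc(OC(C)=O)c(CC=C(C)C)c4)c(=O)oc3c2C)c1` carries a 3-methoxyphenoxy group, and in this assay compound 2 gives 15700 nM; the step of a 1.2-fold lower number from compound 1 to compound 2 (0.06 log units; within the scatter). Compound 3 `COc1ccc(Nc2ccc3cc(NC(=O)c4ccc(OC(C)=O)c(CC=C(C)C)c4)c(=O)oc3c2C)cc1` carries a (4-methoxyphenyl)amino group. In this assay compound 3 gives > 100000 nM, which is a limit of the assay and not a number, so compound 3 stands at the limit of > 100000 nM in this assay, at which 1 of the 3 values shown sits, with only a bound known. The steps to it are an at least 5.4-fold higher number from compound 1 to compound 3 (0.73 log units; beyond the scatter) and an at least 6.3-fold higher number from compound 2 to compound 3 (0.80 log units; beyond the scatter).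

Compound 4 `COCOc1ccc(Cc2ccc3cc(NC(=O)c4ccc(OC(C)=O)c(CC=C(C)C)c4)c(=O)oc3c2C)cc1` changes that same position once more: 4-(methoxymethoxy)benzyl in place of (4-methoxyphenyl)amino on an aromatic carbon. Within the data shown here, the amino link of compound 3 becomes a carbon link, and no measured compound carries such a link, so the measured steps give no direct guide; they show only that the oxygen-linked compounds 1 and 2 sit far lower than compound 3. The expectation is a step from compound 3 to compound 4 of an at least 3.3-fold lower number from compound 3 to compound 4 (0.52 log units; beyond the scatter), placing compound 4 between the oxygen-linked pair and the limit. Compound 4 is therefore estimated at 30000 nM in this assay, with a range from 8000 nM to 120000 nM.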

Compound 4, half-maximal inhibitory concentration: 22700 nM
The estimate for compound 4 lay 1.3-fold (0.12 log units) above the measured number; measured number inside the range.
By their numbers in this assay, from the lowest: compounds 2, 1 and 4 (each within the scatter of the next). At a limit, above all of these: compound 3.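

Moving from the amino link to a benzyl link at this position recovers measurable activity, with an at least 4.4-fold lower number from compound 3 to compound 4 (0.64 log units; beyond the scatter). Compared with the oxygen-linked compounds, the benzyl compound shows no difference that can be told apart from scatter: there is a 1.4-fold higher number from compound 2 to compound 4 (0.16 log units; within the scatter) and a 1.2-fold higher number from compound 1 to compound 4 (0.10 log units; within the scatter), so a carbon link serves here as well as an oxygen link, and an oxygen link is not needed for this level of activity. Among the links shown, only the amino link of compound 3 stands apart, and its value in this assay is a limit of the assay and not a number: the limit of > 100000 nM in this assay, at which 1 of the 4 values shown sits.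

The step to compound 4 changes the link and the group on the outer ring at once, so the compounds shown cannot separate the two changes; a 4-methoxybenzyl group would pair the carbon link with the methoxy group of compound 3. From the compounds shown here alone, it also remains open whether the poor result belongs to the amino link in general, as a methylated nitrogen link or a 4-hydroxybenzyl group could help to show.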